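Halogen swap on the sulfonamide aryl ring of compound 3

The compounds below may be only part of what the source reports. "The series", "measured", "known", "first", "only" and "open" are said of these compounds alone.

Three cyclopropyl-oxazole sulfonamides have been tested so far. Compound 1 `O=S(=O)(Nc1cc(F)cc(F)c1)c1ccc(-c2cnc(C3CC3)o2)cc1` carries a 3,5-difluorophenyl on the sulfonamide nitrogen, and in a functional assay on cells (leukaemia cell line, Homo sapiens) for inhibition, read by sulforhodamine B assay, with a stated time of 48 h (a lower number here means a stronger inhibitor of growth, a higher number a weaker inhibitor of growth), compound 1 gives 2140 nM. Compound 2 `O=S(=O)(Nc1cc(F)cc(Cl)c1)c1ccc(-c2cnc(C3CC3)o2)cc1` gives 1440 nM. Compound 3 `Cc1cc(Cl)cc(NS(=O)(=O)c2ccc(-c3cnc(C4CC4)o3)cc2)c1` gives 175 nM, and its steps to both others are beyond the scatter: a 12-fold lower number from compound 1 to compound 3 (1.09 log units; beyond the scatter) and an 8.2-fold lower number from compound 2 to compound 3 (0.92 log units; beyond the scatter). Compound 3 therefore stands lowest among the three.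

The change from compound 3 to compound 4 `Cc1cc(F)cc(NS(=O)(=O)c2ccc(-c3cnc(C4CC4)o3)cc2)c1` is fluoro in place of chloro on an aromatic carbon. The same kind of change has been measured once already, from compound 2 to compound 1: fluoro in place of chloro on an aromatic carbon, which gave a 1.5-fold higher number from compound 2 to compound 1 (0.17 log units; within the scatter). The surroundings are not identical, however. In compound 2 the carbon that carries the chloro is meta to a fluoro group and meta to a large group, whereas in compound 3 it is meta to a methyl group and meta to a large group. The two cores of compound 2 and compound 3 differ in that one way: methyl in place of fluoro on an aromatic carbon.

Resting on the measured pair, the step from compound 3 to compound 4 is expected to be small, a 1.6-fold higher number from compound 3 to compound 4 (0.20 log units; within the scatter), since compound 2 to compound 1 moved by only a 1.5-fold higher number from compound 2 to compound 1 (0.17 log units; within the scatter). For compound 4 in this assay an estimate of 280 nM is expected, with a plausible range from 120 nM to 700 nM.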

Compound 4, concentration for 50% growth inhibition: 138 nM
Estimate against measurement, compound 4: 2.0-fold (0.31 log units) above; measured number inside the range.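

In this assay the swap of fluoro for chloro on the 3-chloro-5-methylphenyl group gives a 1.3-fold lower number from compound 3 to compound 4 (0.10 log units; within the scatter), and this reads the same as the earlier swap on the other core: the same change on two cores in this assay, a 1.5-fold higher number (0.17 log units; within the scatter) from compound 2 to compound 1 and a 1.3-fold lower number (0.10 log units; within the scatter) from compound 3 to compound 4, 1.9-fold (0.28 log units) apart, within the scatter of two such steps. The methyl group carries across in the same way, with methyl in place of chloro giving a 10-fold lower number from compound 2 to compound 4 (1.02 log units; beyond the scatter) and methyl in place of fluoro giving a 16-fold lower number from compound 1 to compound 4 (1.19 log units; beyond the scatter). Methyl in place of fluoro thus repeats on two cores: the same change on two cores in this assay, an 8.2-fold lower number (0.92 log units; beyond the scatter) from compound 2 to compound 3 and a 16-fold lower number (1.19 log units; beyond the scatter) from compound 1 to compound 4, 1.9-fold (0.28 log units) apart, within the scatter of two such steps. Among these four compounds, then, each change keeps its size from one core to the other, but each comparison rests on only two pairs of closely related compounds in a single assay, so this shows neither why the methyl group matters nor that either change would carry to a more distant core.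

The compounds shown leave open whether an ethyl, methoxy or trifluoromethyl group could stand in place of the methyl group and give a similar number. They also leave open whether these steps would hold if a longer chain or an amine stood in place of the cyclopropyl group on the shared core.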